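The compounds below may be only part of what the source reports. "The series", "measured", "known", "first", "only" and "open" are said of these compounds alone.

Measured in a functional assay on the whole organism with Canis familiaris (Canis lupus familiaris) as the target; a lower number here means that less compound is needed, a higher number that more compound is needed for the effect:
- compound 1 `COc1ccc(-c2nc3cc[nH]cc-3n2)cc1`: 1.7 mg/kg
- compound 2 `COc1ccc(-c2nc3cc[nH]cc-3n2)c(OCCSC)c1`: 1.1 mg/kg
- compound 3 `COc1ccc(-c2nc3cc[nH]cc-3n2)c(OCC[S+](C)[O-])c1`: 5.2 mg/kg

Compound 3 has the highest number of the three, at 5.2 mg/kg. It stands clear of both others: the step of a 3.1-fold higher number from compound 1 to compound 3 (0.49 log units; beyond the scatter) and the step of a 4.7-fold higher number from compound 2 to compound 3 (0.67 log units; beyond the scatter) each lie beyond the scatter. The step of a 1.5-fold lower number from compound 1 to compound 2 (0.19 log units; within the scatter), by contrast, lies within it.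

Compound 4 `CCSCCOc1cc(OC)ccc1-c1nc2cc[nH]cc-2n1` has not yet been measured. It differs from compound 3 in one place: a group of 3 heavy atoms (2 carbon, 1 sulfur; no ring) in place of a group of 3 heavy atoms (1 carbon, 1 oxygen, 1 sulfur; no ring), on a saturated chain carbon, two bonds along the chain from an oxygen on an aromatic ring. The group that enters is ethylsulfanyl.

The step that bears most directly on this change is a 4.7-fold higher number from compound 2 to compound 3 (0.67 log units; beyond the scatter), which leads from the 2-(methylsulfanyl)ethoxy compound to compound 3. Compound 4 reverses that change in part, keeping a sulfanyl chain but with ethyl in place of methyl. No measurement here covers that ethyl-for-methyl difference, so the comparison is only approximate.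

A lower number of somewhat smaller size than that step is therefore expected in this assay. The expected step is a 3.7-fold lower number from compound 3 to compound 4 (0.57 log units; beyond the scatter). For compound 4 the estimated value is 1.4 mg/kg, with an expected range from 0.6 mg/kg to 3.2 mg/kg.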

Compound 4, dose for half-maximal effect: 1 mg/kg
Compound 4: middle estimate off by 1.4-fold (0.15 log units), on the high side, within the range that was stated.
By their numbers in this assay, from the lowest: compounds 4, 2 and 1 (each within the scatter of the next); then compound 3.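

In this assay, swapping the group at the chain end gives a 5.2-fold lower number from compound 3 to compound 4 (0.72 log units; beyond the scatter), so the high number of the sulfoxide-bearing chain now stands apart from a second sulfanyl chain as well as from the first. Methyl in place of hydrogen on a saturated chain carbon bound to a sulfur, the first change shown at the far end of this chain, gives a 1.1-fold lower number from compound 2 to compound 4 (0.04 log units; within the scatter), which lies within the scatter, so ethylsulfanyl and methylsulfanyl cannot be told apart here. The full 2-(ethylsulfanyl)ethoxy group in place of hydrogen on an aromatic carbon gives a 1.7-fold lower number from compound 1 to compound 4 (0.23 log units; within the scatter), also within the scatter, so among these compounds only the chain of compound 3 separates from the compound without a chain.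

From the compounds shown here alone, it remains open whether a longer chain such as propylsulfanyl, or a sulfonyl group, an amine or a carboxylic acid at the chain end, would read like compound 2 and compound 4 or like compound 3. Nothing available here bears on what lies behind these differences.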